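This account rests on a few compounds, and the source may have more. Where it says the series, first, only, none or still open, it means among the compounds named here.

Series notes. Compound 1 `Nc1scc(-c2ccccc2F)c1C(=O)c1ccccc1` gives 68% in a functional assay on CHO cells for agonist activity at adenosine receptor A1 (Homo sapiens), read by fluorescence and ERK phosphorylation, with stated times of 30 min and 1.5 h, tested at 10 uM; a higher number here means a stronger effect of the compound at the concentration tested, a lower number a weaker effect. For the measured compounds named here, compound 2 `Nc1scc(-c2ccc(Cl)cc2)c1C(=O)c1ccccc1` gives 51% in this assay, the lower of the two numbers, with compound 1 as its only neighbour; the single measured step is a number 17 percentage points lower from compound 1 to compound 2 (beyond the scatter). Compound 3 `Nc1scc(-c2ccc(I)cc2)c1C(=O)c1ccccc1` differs from compound 2 by iodo in place of chloro on an aromatic carbon. Going by the values given here, no measured step exchanges one halogen for another, so the step from compound 1 to compound 2, which also moves the substituent, gives no direct guidance; a step within the scatter is expected, a number 1 percentage points lower from compound 2 to compound 3 (within the scatter). Compound 3 is accordingly estimated at 50%, between 30% and 70%.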

Compound 3, a percentage reported as activity, at one concentration (the size of the read-out at that concentration, not a potency): 50%
The estimate for compound 3 equals the measured number at the digits printed; the measured number falls inside the stated range.
By their numbers in this assay, from the lowest: compounds 3 and 2 (each within the scatter of the next); then compound 1.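

With the halogen held at the place para to a large group, chloro and iodo are not told apart in this assay (a number 1 percentage points lower from compound 2 to compound 3 (within the scatter)). The 4-iodophenyl compound also stays clear of the 2-fluorophenyl compound (a number 18 percentage points lower from compound 1 to compound 3 (beyond the scatter)), so the gap to compound 1 does not depend on which of these two larger halogens is carried. No measured evidence bears on this result.

Halogen identity and ring place change together between compound 1 and the other two, so their contributions remain unseparated. Also open, as far as these compounds go, is how an amine or a carboxylic acid on this aromatic carbon would read out.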